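The compounds below may be only part of what the source reports. "The series", "measured", "known", "first", "only" and "open" are said of these compounds alone.

Compound 1 `CC(C)c1cc(OCC(=O)[C@H](CC(=O)O)NC(=O)[C@@H](NC(=O)COc2cccc3ccccc23)C(C)C)no1`: > 200000 nM
Compound 2 `CC(C)[C@H](NC(=O)COc1cccc2ccccc12)C(=O)N[C@@H](CC(=O)O)C(=O)CSc1nc(-c2ccccc2)c(-c2ccccc2)o1`: > 200000 nM
Compound 3 `CC(C)[C@H](NC(=O)COc1cccc2ccccc12)C(=O)N[C@@H](CC(=O)O)C(=O)COn1nnc2ccccc21`: > 200000 nM

In a functional assay on Jurkat cells (Homo sapiens) for inhibition (a higher number here means a weaker inhibitor, a lower number a stronger inhibitor), compound 1 gives > 200000 nM, which is a limit of the assay and not a number. Compound 2 gives > 200000 nM, likewise a limit. Compound 3 gives > 200000 nM, also a limit. All three values sit at the limit of > 200000 nM in this assay, at which 3 of the 3 values shown sit, so compound 3 stands only at a limit, as do the two others. The step that the two limits leave unreadable from compound 1 to compound 3 is therefore unreadable. Compound 4 `CC(C)[C@H](NC(=O)COc1cccc2ccccc12)C(=O)N[C@@H](CC(=O)O)C(=O)COc1nccc2ccccc12` differs from compound 3 by a group of 10 heavy atoms (9 carbon, 1 nitrogen; one six-membered aromatic ring of carbon only, one six-membered aromatic ring with 1 hetero atom) in place of a group of 9 heavy atoms (6 carbon, 3 nitrogen; one five-membered aromatic ring with 3 hetero atoms, one six-membered aromatic ring of carbon only), on an oxygen on a saturated carbon. Within the data shown here, no measured step reads on this change, since every value shown is a limit. Compound 4 is expected to stay near that limit, with an expected step that the limit leaves unreadable from compound 3 to compound 4. The estimate for compound 4 is 300000 nM, in the range 50000 nM to 2000000 nM.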

Compound 4, half-maximal inhibitory concentration: 106000 nM
Compound 4: middle estimate off by 2.8-fold (0.45 log units), on the high side; measured number inside the range.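

In this assay, among these compounds, compound 4 gives 106000 nM, the only number so far for a group on this oxygen on a saturated carbon. Compound 1, compound 2 and compound 3 each stand at a limit of the assay: the limit of > 200000 nM in this assay, at which 3 of the 4 values shown sit.

Isoquinolin-1-yl in place of the earlier groups gives an at least 1.8-fold lower number from compound 3 to compound 4 (0.27 log units; that floor lies within the scatter), and also an at least 1.8-fold lower number from compound 1 to compound 4 (0.27 log units; that floor lies within the scatter). Both steps are floors, so neither establishes a gain beyond the scatter.

The compounds shown leave open whether the nitrogen of isoquinolin-1-yl matters, which a naphthalen-1-yl group on the same oxygen would test. They also leave open whether a plain phenyl group would still give a number.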